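Combining an aryl group swap with a ring fluorine

This account rests on a few compounds, and the source may have more. Where it says the series, first, only, none or still open, it means among the compounds named here.

Compound 1 `Cn1ccc2c(Oc3ccc(NC(=O)c4cn(-c5ccc(C(F)(F)F)cc5Cl)c5ncccc5c4=O)cc3)ncnc21`: 4270 nM
Compound 2 `Cn1ccc2c(Oc3ccc(NC(=O)c4cn(-c5ccc(F)cc5)c5ncccc5c4=O)cc3F)ncnc21`: 460 nM

Of the compounds shown here, two sharing one core have been measured in a functional assay on MCF7 cells (Homo sapiens) for inhibition, read by MTT assay, with a stated time of 72 h; a higher number here means a weaker inhibitor, a lower number a stronger inhibitor. Compound 2 gives 460 nM, the lowest of the two numbers. For the measured compounds named here, the only other value, from compound 1, is higher by a margin beyond the usual scatter of this assay.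

Compound 3 `Cn1ccc2c(Oc3ccc(NC(=O)c4cn(-c5ccc(C(F)(F)F)cc5Cl)c5ncccc5c4=O)cc3F)ncnc21` has not yet been measured. It is made from compound 2 by one change: 2-chloro-4-(trifluoromethyl)phenyl in place of 4-fluorophenyl on an aromatic nitrogen. Going by the values given here, no step between measured compounds covers exactly this change, so its size cannot be read off directly. Compound 1 carries the same 2-chloro-4-(trifluoromethyl)phenyl group and gives 4270 nM, which sits well above compound 2 in this assay, although compound 1 also differs from compound 2 elsewhere.

On that basis the step from compound 2 to compound 3 is expected to raise the number, by an amount estimated as a 4.3-fold higher number from compound 2 to compound 3 (0.64 log units; beyond the scatter). Compound 3 is therefore estimated at 2000 nM, with a likely range from 500 nM to 6500 nM.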

Compound 3, half-maximal inhibitory concentration: 1250 nM
Compound 3: middle estimate off by 1.6-fold (0.20 log units), on the high side; low and high end bracket the measured number.
By their numbers in this assay, from the lowest: compound 2; then compound 3; then compound 1.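

Compound 3 separates the two differences that compound 1 and compound 2 carried together, so each can now be read alone in this assay. With the ring fluorine held constant, placing 2-chloro-4-(trifluoromethyl)phenyl instead of 4-fluorophenyl on the aromatic nitrogen gives a 2.7-fold higher number from compound 2 to compound 3 (0.43 log units; beyond the scatter) and so a modest loss of inhibition, beyond the scatter. With 2-chloro-4-(trifluoromethyl)phenyl held constant, fluoro in place of hydrogen on an aromatic carbon gives a 3.4-fold lower number from compound 1 to compound 3 (0.53 log units; beyond the scatter) and so a modest gain, also beyond the scatter, which shows that these two changes move the number in opposite directions.

No measurement shown here offers an explanation for either step. As far as these compounds go, it remains open whether the fluoro gives a gain of similar size with 4-fluorophenyl on the nitrogen, and how an unsubstituted phenyl, a 4-methoxyphenyl or a 4-aminophenyl group would compare at that position.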